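The source may report more compounds than this note shows. Statements on the series, on what has been measured and on what is new or still open speak of the compounds shown alone.

Compound 1, `N#Cc1ccc(N2CCc3cc(-c4cnc5ccccc5c4)ccc3C2)cc1C(F)(F)F`, gives 25900 nM in a functional assay on CWR22R cells (Homo sapiens) for antiproliferative activity, read by CCK-8 assay, with a stated time of 6 days; on this read-out higher numbers stand for weaker inhibition and lower numbers for stronger inhibition.
Compound 2, `N#Cc1ccc(N2CCCc3c(-c4cccnc4)cccc32)cc1C(F)(F)F`, gives 12300 nM in this assay.
Compound 3, `CCN(c1ccc(C#N)c(Cl)c1)c1cc(-c2ccoc2)ccc1C`, gives only > 30000 nM in this assay, and this is a limit of the assay, not a number.

Among the three measured compounds, compound 3 is the only one without a numerical value: it sits at the limit of > 30000 nM in this assay, at which 1 of the 3 values shown sits, so its exact place cannot be fixed, while compounds 1 and 2 both give numbers that fall within the measured range. For the measured compounds named here, no two measured compounds differ in a single place, so no measured step is available to calibrate the change about to be considered.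

Compound 4, `CCN(c1ccc(C#N)c(Cl)c1)c1cc(-c2cccnc2)ccc1C`, differs from compound 3 in one place: pyridin-3-yl in place of furan-3-yl on an aromatic carbon. Since compound 3 offers only a limit, any step from it can be judged only loosely. The expectation is that the step of an at least 1.5-fold lower number from compound 3 to compound 4 (0.17 log units; that floor lies within the scatter) brings compound 4 back into the range where a number is read, but not by a wide margin, since compounds 1 and 2 show that the measured members of this set inhibit only weakly. Compound 4 is therefore estimated at 20000 nM, with an expected range from 6000 nM to 60000 nM, and a real chance that only a limit is reported again.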

Compound 4, half-maximal inhibitory concentration: 2000 nM
Compound 4: middle estimate off by 10-fold (1.00 log units), on the high side, outside the stated range (below it).
By their numbers in this assay, from the lowest: compound 4; then compound 2; then compound 1. At a limit, above all of these: compound 3.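

Replacing furan-3-yl with pyridin-3-yl on this aromatic carbon, meta to a large group and para to a methyl group, gives an at least 15-fold lower number from compound 3 to compound 4 (1.17 log units; beyond the scatter), which shows that the ring held at this one position can decide whether this assay yields a number at all. The two groups match in their counts of hetero atoms, hydrogen-bond donors and hydrogen-bond acceptors, and neither carries a net charge, so those counts do not separate them; they differ in ring size and in the hetero atom, oxygen in the five-membered ring and nitrogen in the six-membered one. The size of this step remains a floor and not a measured difference, because compound 3 has only a limit: the limit of > 30000 nM in this assay, at which 1 of the 4 values shown sits.

The compounds shown cannot tell whether the ring size or the ring nitrogen matters more, since both change together in this single step. They also leave open how this position would respond to a phenyl ring, a pyridin-4-yl ring or a morpholine, and whether the same change would carry over to another core.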